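Replacing Methyl with 4-Methylphenyl on a Ring Nitrogen

A few compounds are considered here, and "the series" means these few. Any claim that something is new, unique, unknown or untested is made for them only; others in the source may bear on it.

Compound 1 `CN1CCN(Cc2csc(N)c2C(=O)c2ccc(Cl)cc2)CC1` gives 1.7 nM in an assay on CHO cells for displacement of a labelled ligand from adenosine receptor A1 (Homo sapiens) (a lower number here means tighter binding, a higher number weaker binding), the lowest of the three numbers recorded, although compound 2 `Nc1scc(CN2CCN(c3ccccc3)CC2)c1C(=O)c1ccc(Cl)cc1` at 1.9 nM and compound 3 `Nc1scc(CN2CCN(c3ccc(F)cc3)CC2)c1C(=O)c1ccc(Cl)cc1` at 1.8 nM both sit within the scatter of it. Compound 4 `Cc1ccc(N2CCN(Cc3csc(N)c3C(=O)c3ccc(Cl)cc3)CC2)cc1` differs from compound 1 by 4-methylphenyl in place of methyl on an amine nitrogen in a ring. For the measured compounds named here, two measured steps bear directly on this change: a 1.1-fold higher number from compound 1 to compound 2 (0.05 log units; within the scatter) and a 1.1-fold higher number from compound 1 to compound 3 (0.02 log units; within the scatter), both within the scatter, and the further step a 1.1-fold lower number from compound 2 to compound 3 (0.02 log units; within the scatter) also moved little. Since neither phenyl nor 4-fluorophenyl on the amine nitrogen in the ring shifted the number, the 4-methylphenyl is expected to leave it essentially unchanged, giving a 1.1-fold higher number from compound 1 to compound 4 (0.02 log units; within the scatter). For compound 4 the estimate in this assay is 1.8 nM, with a range from 1 nM to 3.2 nM.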

Compound 4, dissociation constant: 1.7 nM
Compound 4: the middle estimate sits 1.1-fold (0.02 log units) above what was measured, and the stated range covers the measured number.
By their numbers in this assay, from the lowest: compounds 1, 4, 3 and 2 (each within the scatter of the next).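

In this assay, 4-methylphenyl on the amine nitrogen in the ring gives no change at the digits printed from compound 1 to compound 4 (within the scatter), so this position has now held methyl, phenyl, 4-fluorophenyl and 4-methylphenyl with every step within the scatter. The new compound also adds a methyl on the aromatic ring: methyl in place of fluoro gives a 1.1-fold lower number from compound 3 to compound 4 (0.02 log units; within the scatter), and methyl in place of hydrogen gives a 1.1-fold lower number from compound 2 to compound 4 (0.05 log units; within the scatter). Neither change moves the number beyond the scatter.

No measurement shown accounts for this flat response. As far as these compounds go, whether a carboxylic acid or an amine on that aromatic ring, or a longer chain on the ring nitrogen, would shift the number remains open.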